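Notes on the amide substituent series

The source may report more compounds than this note shows. Statements on the series, on what has been measured and on what is new or still open speak of the compounds shown alone.

Compound 1 `O=C(CSc1nc(Nc2ccccc2)c2ccccc2n1)Nc1ccccc1F` carries a 2-fluorophenyl on the amide-type nitrogen of the shared core. In a functional assay on MDA-MB-231 cells (Homo sapiens) for inhibition, read by MTT assay, with a stated time of 72 h (a lower number here means a stronger inhibitor, a higher number a weaker inhibitor), compound 1 gives only a limit, > 50000 nM, and no number. Compound 2 `O=C(CSc1nc(Nc2ccccc2)c2ccccc2n1)Nc1ccccc1Cl` gives 24400 nM in this assay, and compound 3 `O=C(CSc1nc(Nc2ccccc2)c2ccccc2n1)Nc1ccccc1Br` gives 14100 nM. The step of an at least 2.0-fold lower number from compound 1 to compound 2 (0.31 log units; beyond the scatter) and the step of an at least 3.5-fold lower number from compound 1 to compound 3 (0.54 log units; beyond the scatter) both move away from the limit, while the step of a 1.7-fold lower number from compound 2 to compound 3 (0.24 log units; within the scatter) stays within the scatter. With three compounds, one of them sitting at the limit (the limit of > 50000 nM in this assay, at which 1 of the 3 values shown sits), the reading is only that the substituent on this phenyl shifts the number, with no pattern that can be carried to groups of another kind.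

Compound 4 `O=C(CSc1nc(Nc2ccccc2)c2ccccc2n1)Nc1cccc([N+](=O)[O-])c1` differs from compound 1 by 3-nitrophenyl in place of 2-fluorophenyl on an amide-type nitrogen. Within the data shown here, none of the measured steps introduces a nitro group, so they bear on the step to compound 4 only in showing that the number responds to changes on this phenyl, and that the response so far has stayed modest. The expected step of an at least 1.6-fold lower number from compound 1 to compound 4 (0.22 log units; that floor lies within the scatter) is therefore small and uncertain, and a limit for compound 4 is again plausible. For compound 4 the estimate in this assay is 30000 nM, expected within 8000 nM to 100000 nM.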

Compound 4, half-maximal inhibitory concentration: 33000 nM
The estimate for compound 4 lay 1.1-fold (0.04 log units) below the measured number; the measured number falls inside the stated range.
By their numbers in this assay, from the lowest: compounds 3, 2 and 4 (each within the scatter of the next, the first and the last beyond it). At a limit, above all of these: compound 1.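

In this assay, a phenyl carrying no halogen now gives a measured number on this amide-type nitrogen, so a number in this range is not confined to the halogen-bearing groups of compounds 2 and 3. The 3-nitrophenyl group shows no separation from 2-chlorophenyl in the step of a 1.4-fold higher number from compound 2 to compound 4 (0.13 log units; within the scatter), while it does separate from 2-bromophenyl in the step of a 2.3-fold higher number from compound 3 to compound 4 (0.37 log units; beyond the scatter), so the two halogen-bearing groups no longer stand together against the new group. The step of an at least 1.5-fold lower number from compound 1 to compound 4 (0.18 log units; that floor lies within the scatter) starts from a limit and its floor does not clear the scatter, so it settles nothing firm about 3-nitrophenyl against 2-fluorophenyl: the limit of > 50000 nM in this assay, at which 1 of the 4 values shown sits.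

The step to compound 4 changes both the substituent and its place on the phenyl, and the compounds shown cannot separate the two; 2-nitrophenyl on the same nitrogen would bear directly on this. As far as these compounds go, how an amine or a carboxylic acid on this phenyl, or a longer chain in place of the phenyl, would read in this assay also remains open.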